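The compounds below may be only part of what the source reports. "The series", "measured", "known", "first", "only" and "open" are said of these compounds alone.

Among the compounds with values here, compound 3, whose structure is `Cn1ncc(Cl)c1-c1cc(C(=O)N[C@@H]2CN[C@H](CC(N)=O)C[C@H]2c2ccc(Cl)c(Cl)c2)oc1Cl`, is one of three compounds measured in a functional assay on OVCAR-8 cells (Homo sapiens) for antiproliferative activity; a lower number here means a stronger inhibitor, a higher number a weaker inhibitor. In this assay compound 3 gives 1000 nM, the second highest of the three numbers. Compound 1, with the structure `Cn1ncc(Cl)c1-c1cc(C(=O)N[C@@H]2CNCC[C@H]2c2ccc(C(F)(F)F)cc2)oc1Cl`, gives in this assay the value 120 nM, a lower number and so a stronger inhibitor, and the gap to compound 3 lies beyond the usual scatter. Compound 2, with the structure `O=C(N[C@@H]1CNCC[C@H]1c1ccc(Cl)cc1)c1ccc(-c2ncnc3c2CCC3O)s1`, gives in this assay the value 24100 nM, the highest of the three and again beyond the scatter from compound 3.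

Compound 4, with the structure `CCC[C@@H]1C[C@@H](c2ccc(Cl)c(Cl)c2)[C@H](NC(=O)c2cc(-c3c(Cl)cnn3C)c(Cl)o2)CN1`, has not yet been measured. It differs from compound 3 in one place: ethyl in place of carbamoyl on a saturated chain carbon bound to a saturated ring carbon. Nothing measured here shows how such an exchange on a saturated chain carbon bound to a saturated ring carbon affects the read-out, so the expectation rests on compound 3 alone. The step from compound 3 to compound 4 is expected to be small, a 1.3-fold lower number from compound 3 to compound 4 (0.10 log units; within the scatter), with no direction clearly favoured beyond the scatter. For compound 4 the value in this assay is therefore estimated at 800 nM, within a range from 200 nM to 3000 nM.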

Compound 4, half-maximal inhibitory concentration: 1620 nM
Estimate against measurement, compound 4: 2.0-fold (0.31 log units) below, and the stated range covers the measured number.
By their numbers in this assay, from the lowest: compound 1; then compounds 3 and 4 (each within the scatter of the next); then compound 2.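

In this assay, within the data shown here, putting ethyl in place of carbamoyl on a saturated chain carbon bound to a saturated ring carbon gives a 1.6-fold higher number from compound 3 to compound 4 (0.21 log units; within the scatter); this is the first direct reading of a change at this position, and the assay does not separate the two compounds. The group that leaves carries a hydrogen-bond donor and a hydrogen-bond acceptor and the group that enters carries neither, so for this pair, losing both leaves the number within the usual scatter. Nothing available here explains this result.

Still open, as far as these compounds go, is what an amine, a carboxylic acid or a longer chain such as hexyl would do at this position. This single pair also cannot show whether the same exchange would give a similar step on another core.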